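This account rests on a few compounds, and the source may have more. Where it says the series, first, only, none or still open, it means among the compounds named here.

Compound 1 `CCCc1cc(NC2CCC2)c2cc(NC(=O)/C=C/c3ccc(C(F)(F)F)cc3)ccc2n1` and compound 2 `CCCc1cc(N)c2cc(NC(=O)/C=C/c3ccc(CC)cc3)ccc2n1` share a core that carries a cinnamide-type arm. In a functional assay on HEK293 cells for activation of melanin-concentrating hormone receptor 1 (Homo sapiens), read by inositol phosphate accumulation (a higher number here means that more compound is needed for the effect, a lower number that less compound is needed), compound 1 gives 270 nM, the highest of the two numbers shown, while compound 2 gives 160 nM; the two values lie within the scatter of each other, so no order can be read from them. Compound 3 `CCCc1cc(NC)c2cc(NC(=O)/C=C/c3ccc(C(F)(F)F)cc3)ccc2n1` differs from compound 1 only by methyl in place of cyclobutyl on a nitrogen on an aromatic ring. For the measured compounds named here, with no measured step of this kind at hand, the change is expected to move the number little: compound 3 is estimated at 250 nM (from 80 nM to 800 nM), a step of a 1.1-fold lower number from compound 1 to compound 3 (0.03 log units; within the scatter) that is expected to stay inside the scatter.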

Compound 3, half-maximal effective concentration: 150 nM
Estimate against measurement, compound 3: 1.7-fold (0.22 log units) above; measured number inside the range.
By their numbers in this assay, from the lowest: compounds 3, 2 and 1 (each within the scatter of the next).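

Methyl in place of cyclobutyl gives the first direct comparison at this nitrogen. In this assay the step is a 1.8-fold lower number from compound 1 to compound 3 (0.26 log units; within the scatter) and stays within the scatter, so the two groups cannot be told apart here. The group on this nitrogen can therefore go from one with 4 heavy atoms and a ring to one with 1 heavy atom and no ring without a clear change in the number. No data here offer a reason for this result.

Still open, going by these compounds, is whether a much larger or different group on this nitrogen, such as a longer chain, a benzyl group or one carrying a carboxylic acid, would move the number beyond the scatter.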